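The source may hold more compounds than are shown below. What is called first, only, known or untested is meant among the compounds shown, and "the series" means these compounds.

Going by the values given here, compound 2 `CCOC(=O)c1cc(-c2cccc(OC(=O)NC3CCCCC3)c2)n(-c2ccc(OC)cc2)n1` gives 103 nM in an assay on isolated protein for inhibition of Fatty-acid amide hydrolase 1 (Homo sapiens), read by fluorescence, with a stated time of 30 min (on this read-out lower numbers stand for stronger inhibition and higher numbers for weaker inhibition), one of only two numbers measured so far; the other belongs to compound 1 `CCOC(=O)c1cc(-c2cccc(OC(=O)NC3CCCCC3)c2)n(CC)n1`, which with 101 nM lies within the scatter of it. Among the compounds with values here, the single step seen to date, a 1.0-fold higher number from compound 1 to compound 2 (0.01 log units; within the scatter), came from putting 4-methoxyphenyl in place of ethyl on an aromatic nitrogen, and it left the number essentially where it was. Compound 3 `CCOC(=O)c1cc(-c2cccc(OC(=O)NC3CCCCC3)c2)n(-c2ccc(Cl)cc2Cl)n1` carries 2,4-dichlorophenyl in place of 4-methoxyphenyl on an aromatic nitrogen. Within the data shown here, that earlier step is the only one bearing on this change, as it concerns the same aromatic nitrogen, and its small size suggests that the group on that nitrogen has little hold over the number. Compound 3 is therefore expected to show a 1.0-fold lower number from compound 2 to compound 3 (0.01 log units; within the scatter), nothing beyond the scatter. The estimate for compound 3 in this assay is 100 nM, with a range from 40 nM to 250 nM.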

Compound 3, half-maximal inhibitory concentration: 123 nM
For compound 3 the middle estimate is 1.2-fold (0.09 log units) below the measured one; the range from low to high includes it.
By their numbers in this assay, from the lowest: compounds 1, 2 and 3 (each within the scatter of the next).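

In this assay, the change to 2,4-dichlorophenyl gives a 1.2-fold higher number from compound 2 to compound 3 (0.08 log units; within the scatter) and, measured against ethyl, a 1.2-fold higher number from compound 1 to compound 3 (0.09 log units; within the scatter) as well. The earlier pair had shown only that one aromatic ring, 4-methoxyphenyl, could replace ethyl on this nitrogen; this result adds a ring with two chlorine atoms and no oxygen, and all three groups now lie within the scatter of one another. Nothing available explains why the number stays so flat across these groups.

As far as these compounds go, it remains open whether a group of another kind on this nitrogen, such as an amine, a carboxylic acid or a longer chain, would move the number beyond the scatter. The ethoxycarbonyl group is common to all three compounds, so the effect of replacing it with a carboxylic acid or an amide cannot be read from them.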